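The compounds below may be only part of what the source reports. "The series", "measured", "known", "first", "only" and "open" are said of these compounds alone.

Measured in a functional assay on HT-29 cells (Homo sapiens) for inhibition, read by luminescence and CellTiter-Glo, with a stated time of 24 h; on this read-out higher numbers stand for an effect only at larger amounts of compound and lower numbers for an effect already at smaller amounts:
- Compound 1 `CN1C(=S)[C@@H](NC(=O)c2nc(Cc3ccccc3)n(CCCF)n2)COc2ccccc21`: 4760 nM
- Compound 2 `CN1C(=S)[C@@H](NC(=O)c2nc(Cc3ccccc3)n(C3CCCCC3)n2)COc2ccccc21`: 4000 nM
- Compound 3 `CN1C(=S)[C@@H](NC(=O)c2nc(Cc3ccccc3)n(C3COC3)n2)COc2ccccc21`: 916 nM

These three compounds share one core and differ only in the group on an aromatic nitrogen. Compound 3, which carries oxetan-3-yl there, has the lowest number of the three, so it shows its effect at the smallest amount. Compound 4 `CN1C(=S)[C@@H](NC(=O)c2nc(Cc3ccccc3)n(C3CCOCC3)n2)COc2ccccc21` has not yet been measured. It has oxan-4-yl in place of oxetan-3-yl on an aromatic nitrogen.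

All three measured steps bear on this change. Two are modest: a 5.2-fold lower number from compound 1 to compound 3 (0.72 log units; beyond the scatter) and a 4.4-fold lower number from compound 2 to compound 3 (0.64 log units; beyond the scatter). The third, a 1.2-fold lower number from compound 1 to compound 2 (0.08 log units; within the scatter), shows no real difference. The oxan-4-yl group has a six-membered non-aromatic ring, as the cyclohexyl of compound 2 does, and an oxygen in its ring, as the oxetan-3-yl of compound 3 does. Among the measured compounds shown here, no measured compound combines the two features, so this is only a rough guide. A number between compound 3 at 916 nM and compound 2 at 4000 nM therefore seems likely. The expected change is a modest rise, possibly close to the scatter: a 1.9-fold higher number from compound 3 to compound 4 (0.27 log units; within the scatter). For compound 4 the estimated value is 1700 nM, with an expected range from 650 nM to 4500 nM.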

Compound 4, half-maximal effective concentration: 2260 nM
Compound 4: the middle estimate sits 1.3-fold (0.12 log units) below what was measured, within the range that was stated.
By their numbers in this assay, from the lowest: compound 3; then compounds 4, 2 and 1 (each within the scatter of the next, the first and the last beyond it).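

In this assay, the change from oxetan-3-yl to oxan-4-yl gives a 2.5-fold higher number from compound 3 to compound 4 (0.39 log units; beyond the scatter). Both groups carry one oxygen in a non-aromatic ring, so that oxygen alone does not preserve the low number of compound 3 when a six-membered ring replaces the four-membered one. Comparing the two six-membered rings gives a 1.8-fold lower number from compound 2 to compound 4 (0.25 log units; within the scatter), so in this set, replacing cyclohexyl with oxan-4-yl makes no clear difference, even though the same oxan-4-yl group gives a 2.1-fold lower number from compound 1 to compound 4 (0.32 log units; beyond the scatter), a modest step that compound 2 did not show against compound 1.

The data offer no measured explanation for why these steps have the sizes they do. The compounds shown leave open where a five-membered ring with one oxygen, such as oxolan-3-yl, would fall on this aromatic nitrogen, and whether a four-membered ring holding an amine, such as azetidin-3-yl, would match the oxetan-3-yl of compound 3.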